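This account rests on a few compounds, and the source may have more. Where it says the series, first, only, none or still open, it means among the compounds named here.

Compound 1 `COc1cc2ncnc(Nc3cccc(F)c3)c2cc1OCCCCC(=O)Nc1ccc(S(N)(=O)=O)cc1` gives > 40000 nM in a functional assay on NCI-H1975 cells (Homo sapiens) for antiproliferative activity, read by MTT assay, with a stated time of 72 h (on this read-out lower numbers stand for stronger inhibition and higher numbers for weaker inhibition), which is a limit of that assay (the limit of > 40000 nM in this assay, at which 1 of the 2 values shown sits). Compound 2 `COc1ccccc1Nc1ncnc2cc(OC)c(OCCCCC(=O)Nc3ccc(S(N)(=O)=O)cc3)cc12` gives 8030 nM in this assay.

Within the data shown here, compound 2 thus holds the only measured number; the step of an at least 4.9-fold lower number from compound 1 to compound 2 (0.69 log units; beyond the scatter) is the one measured change. Compound 3 `COc1cc2ncnc(Nc3ccccc3)c2cc1OCCCCC(=O)Nc1ccc(S(N)(=O)=O)cc1` differs from compound 2 by hydrogen in place of methoxy on an aromatic carbon. Among the measured compounds shown here, no measured step removes a methoxy alone, since the step from compound 1 already exchanges both group and its place. Compound 3 is therefore expected to show a step of a 1.9-fold higher number from compound 2 to compound 3 (0.27 log units; within the scatter), leaning weaker but uncertain. Compound 3 is estimated at 15000 nM, within 5000 nM to 45000 nM.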

Compound 3, half-maximal inhibitory concentration: 14100 nM
Estimate against measurement, compound 3: 1.1-fold (0.03 log units) above, and the stated range covers the measured number.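

In this assay, hydrogen in place of methoxy gives a 1.8-fold higher number from compound 2 to compound 3 (0.24 log units; within the scatter), so at this place the methoxy is not shown to change the number. Hydrogen in place of fluoro gives an at least 2.8-fold lower number from compound 1 to compound 3 (0.45 log units; beyond the scatter), which shows that the gain over the fluoro compound does not depend on having a methoxy on this ring. The value of compound 1 is a limit of the assay: the limit of > 40000 nM in this assay, at which 1 of the 3 values shown sits.

The compounds shown leave open whether an amine or a chloro on this ring would move the number beyond the scatter. They also leave open what a longer chain would do.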